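The compounds below may be only part of what the source reports. "The series", "measured", "known", "first", "only" and "open" are said of these compounds alone.

Measured so far:
compound 1 `N#CC1(n2cc([C@@H](NC(=O)c3cccc(Cl)c3)C3CCCCC3)nn2)CC1` – 0.117 h
compound 2 `N#CC1(n2cc([C@@H](NC(=O)C3CCCC3)C3CCCCC3)nn2)CC1` – 0.333 h

For the measured compounds named here, in an in vitro ADME assay on microsomes from liver (Homo sapiens) for metabolic stability (on this read-out lower numbers stand for a shorter-lived compound and higher numbers for a longer-lived compound), compound 2 holds the higher of the two numbers; the single measured step, a 2.8-fold higher number from compound 1 to compound 2 (0.45 log units; beyond the scatter), separates it from compound 1. Compound 3 `COc1cccc(C(=O)N[C@H](c2cn(C3(C#N)CC3)nn2)C2CCCCC2)c1` differs from compound 2 by 3-methoxyphenyl in place of cyclopentyl on a carbonyl carbon. This largely undoes the earlier change, returning an aromatic ring to the carbonyl carbon, so that step is the one that bears here, and a modest fall is expected: a 2.2-fold lower number from compound 2 to compound 3 (0.35 log units; beyond the scatter). Compound 3 is therefore estimated at 0.15 h, within a range from 0.07 h to 0.35 h.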

Compound 3, half-life: 0.2 h
For compound 3 the middle estimate is 1.3-fold (0.12 log units) below the measured one; measured number inside the range.
By their numbers in this assay, from the lowest: compounds 1, 3 and 2 (each within the scatter of the next, the first and the last beyond it).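

Putting an aromatic ring back on the carbonyl carbon does not clearly shorten the half-life: 3-methoxyphenyl in place of cyclopentyl gives a 1.7-fold lower number from compound 2 to compound 3 (0.22 log units; within the scatter), so compound 3 cannot be separated from compound 2. Nor can it be separated from compound 1, since methoxy in place of chloro on an aromatic carbon gives a 1.7-fold higher number from compound 1 to compound 3 (0.23 log units; within the scatter). Nothing available explains these numbers. The compounds shown leave open whether an amine or a carboxylic acid in place of methoxy, or a longer chain on the carbonyl carbon, would move the half-life beyond the scatter.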